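This account rests on a few compounds, and the source may have more. Where it says the series, first, only, none or still open, it means among the compounds named here.

Compound 1 `OC[C@H]1O[C@@H](n2cnc3c(NCc4cccc(F)c4)ncnc32)[C@H](O)[C@@H]1O` gives 7600 nM in a functional assay on K562 cells (Homo sapiens) for antiproliferative activity, with a stated time of 72 h; on this read-out higher numbers stand for weaker inhibition and lower numbers for stronger inhibition. Compound 2 `Cc1cccc(CNc2ncnc3c2ncn3[C@@H]2O[C@H](CO)[C@@H](O)[C@H]2O)c1` reaches only a limit of this assay, > 166000 nM. Compound 3 `COc1cc(CNc2ncnc3c2ncn3[C@@H]2O[C@H](CO)[C@@H](O)[C@H]2O)cc(OC)c1` likewise reaches only a limit, > 166000 nM.

Compound 3 therefore stands at the limit of > 166000 nM in this assay, at which 2 of the 3 values shown sit, with no number of its own. Compound 4 `OC[C@H]1O[C@@H](n2cnc3c(NCc4ccccc4OC(F)F)ncnc32)[C@H](O)[C@@H]1O` is not yet measured and differs from compound 3 in one group: 2-(difluoromethoxy)phenyl in place of 3,5-dimethoxyphenyl on a saturated chain carbon bound to a nitrogen on an aromatic ring. Among the compounds with values here, no measured step exchanges exactly these two groups. The two steps that alter the same group, an at least 21-fold higher number from compound 1 to compound 2 (1.33 log units; beyond the scatter) and an at least 21-fold higher number from compound 1 to compound 3 (1.33 log units; beyond the scatter), were both large losses, while a step that the two limits leave unreadable from compound 2 to compound 3 cannot be sized. Because compound 3 sits at the limit of > 166000 nM in this assay, at which 2 of the 3 values shown sit, compound 4 is expected to show an at least 5.5-fold lower number from compound 3 to compound 4 (0.74 log units; beyond the scatter) toward stronger inhibition. Compound 4 is estimated at 30000 nM, within 5000 nM to 166000 nM.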

Compound 4, half-maximal inhibitory concentration: > 166000 nM
Compound 4 gave a limit, no number (the forecaster's own chance of this, stated with the estimate: 35%); middle value at least 5.5-fold (0.74 log units) away from the limit.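

Replacing 3-fluorophenyl with 2-(difluoromethoxy)phenyl gives an at least 21-fold higher number from compound 1 to compound 4 (1.33 log units; beyond the scatter) in this assay, a third large loss at this place. Fluorine in the new group is therefore not enough to keep the activity of compound 1. The steps from compound 2 and from compound 3 to compound 4 cannot be read, and compound 4 joins the others at a limit: the limit of > 166000 nM in this assay, at which 3 of the 4 values shown sit.

From the compounds shown here alone, whether unsubstituted phenyl or 3-chlorophenyl on this carbon would give a readable number stays open. Going by these compounds, it is also open whether 2-fluorophenyl would hold the activity of compound 1.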